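Working notes: replacing the aryl group of compound 2

The source may hold more compounds than are shown below. What is called first, only, known or untested is meant among the compounds shown, and "the series" means these compounds.

Measured in a functional assay on B16-F0 cells (Mus musculus) for inhibition, read by CCK-8 assay, with a stated time of 48 h (on this read-out higher numbers stand for weaker inhibition and lower numbers for stronger inhibition), so far:
- compound 1 `COc1cc(-c2ccnc3cc(-c4ccc(C)cc4)nn23)cc(OC)c1OC` gives 21 nM
- compound 2 `COc1cc(-c2ccnc3cc(-c4ccc(C(F)(F)F)cc4)nn23)cc(OC)c1OC` gives 1770 nM

Compound 2 holds the higher of the two numbers in this assay and thus the weaker inhibition. The change to compound 3 `COc1cc(-c2ccnc3cc(-c4ccc5ccn(C)c5c4)nn23)cc(OC)c1OC` is 1-methyl-1H-indol-6-yl in place of 4-(trifluoromethyl)phenyl on an aromatic carbon. For the measured compounds named here, the one measured step bearing on it is an 84-fold higher number from compound 1 to compound 2 (1.93 log units; beyond the scatter) with trifluoromethyl in place of methyl, and it is large. Going by the values given here, compound 3 no longer carries trifluoromethyl, so a large step to a lower number in this assay is expected, although no indolyl compound has been measured. The expected step is a 44-fold lower number from compound 2 to compound 3 (1.65 log units; beyond the scatter) by this estimate. Compound 3 is expected near 40 nM (estimated range 8 nM to 300 nM).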

Compound 3, half-maximal inhibitory concentration: 657 nM
Estimate against measurement, compound 3: 16-fold (1.22 log units) below; measured number outside the range, above it.
By their numbers in this assay, from the lowest: compound 1; then compound 3; then compound 2.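

In this assay, losing trifluoromethyl does not by itself recover the low number: 1-methyl-1H-indol-6-yl brings only a 2.7-fold lower number from compound 2 to compound 3 (0.43 log units; beyond the scatter) and still stands at a 31-fold higher number from compound 1 to compound 3 (1.50 log units; beyond the scatter) in the comparison with 4-methylphenyl. Among the three groups at this position, a low number is so far seen only with 4-methylphenyl, and a second aromatic ring in the group does not reproduce it. No evidence is available that bears on this result.

Open, as far as these compounds go, is whether the methyl itself matters: unsubstituted phenyl, 4-ethylphenyl, 4-methoxyphenyl or 4-aminophenyl at this position would address that.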